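This account rests on a few compounds, and the source may have more. Where it says the series, first, only, none or still open, it means among the compounds named here.

Within the data shown here, compound 2 `N#CC1=C(NCN2CCCCC2)N(c2ccccc2)C(=O)N2CCCCC(N3CCCC3)C12` is the weaker of the two compounds measured so far in a functional assay on the whole organism (strain albino) for inhibition, with Rattus norvegicus as the target, read by paw edema, with stated times of 1 h and 3 h, at a dose of 20 mmol/kg by the intraperitoneal route; a lower number here means a weaker effect, a higher number a stronger effect of the compound at the dose given. In this assay, among the measured compounds shown here, compound 2 gives 42.1%, the lowest of the two numbers known. Its nearest neighbour is compound 1 `N#CC1=C(/N=C/Nc2ccc([N+](=O)[O-])cc2)N(c2ccccc2)C(=O)N2CCCCC(N3CCCC3)C12`, which in this assay gives 85.6%. For the measured compounds named here, the only measured step, a number 43.5 percentage points lower from compound 1 to compound 2 (beyond the scatter), is a large drop and concerns the same position of the shared core that is changed again here.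

The compound now in question is compound 3 `CCOC(=O)C(=O)NC1=C(C#N)C2C(N3CCCC3)CCCCN2C(=O)N1c1ccccc1`. It differs from compound 2 in one place: (ethoxycarbonyl)carbonyl in place of (piperidin-1-yl)methyl on an amine nitrogen. Going by the values given here, no measured step pairs a (piperidin-1-yl)methyl group against an (ethoxycarbonyl)carbonyl group on this amine nitrogen, so the step of a number 43.5 percentage points lower from compound 1 to compound 2 (beyond the scatter) can only show that this position is sensitive, not in which direction the new group will move the number. The two groups replaced across the known pair were also unlike the group entering now.

On that basis the expectation for compound 3 is a modest rise, a number 17.9 percentage points higher from compound 2 to compound 3 (beyond the scatter), with wide uncertainty. Compound 3 is therefore estimated at 60%, within a range from 30% to 85%.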

Compound 3, a percentage reported as inhibition, in the whole organism at one dose (the size of the read-out at that dose, not a potency): 91.5%
Estimate against measurement, compound 3: 31.5 percentage points below, and the stated range ends below it.
By their numbers in this assay, from the lowest: compound 2; then compounds 1 and 3 (each within the scatter of the next).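

The position on the amine nitrogen can now be seen to move the read-out upward as well as downward: in this assay there is a number 49.4 percentage points higher from compound 2 to compound 3 (beyond the scatter), a step of about the same size as the drop seen earlier, so (piperidin-1-yl)methyl is the group that stands apart among the three compounds. The acyclic (ethoxycarbonyl)carbonyl group and the much larger group of compound 1, which carries an aromatic ring, give results that cannot be told apart, with a number 5.9 percentage points higher from compound 1 to compound 3 (within the scatter), so among these compounds an aromatic ring in this substituent is not needed for a read-out at this level. Nothing available here explains why these groups differ as they do.

The compounds shown leave open whether the ethyl ester part of the entering group matters, as against a carboxylic acid or a plain acetyl group on the same amine nitrogen. They also do not separate the piperidine ring of the low compound from its methylene link, which a directly acylated piperidine or an open-chain dimethylaminomethyl group could address.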